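Oxime ether chain extended: ethyl to cyclohexyl

This account rests on a few compounds, and the source may have more. Where it says the series, first, only, none or still open, it means among the compounds named here.

Measured so far:
- compound 1, `CCCO/N=C/c1c(N)ncnc1Oc1ccc2[nH]c(C)cc2c1F`: 30 nM in a functional assay on HCT-116 cells (Homo sapiens) for antiproliferative activity; a lower number here means a stronger inhibitor, a higher number a weaker inhibitor
- compound 2, `CO/N=C/c1c(N)ncnc1Oc1ccc2[nH]ccc2c1F`: 365 nM in this assay

Compound 1 has the lowest number of the two in this assay; compound 2 gives a higher number, and that gap lies beyond the usual scatter. Compound 2 differs from compound 1 in more than one place, so its weaker result cannot be tied to a single change.

Compound 3, `Cc1cc2c(F)c(Oc3ncnc(N)c3/C=N/OCC3CCCCC3)ccc2[nH]1`, has not yet been measured in this assay. It differs from compound 1 in one place: cyclohexyl in place of ethyl on a saturated chain carbon bound to an oxygen on an unsaturated carbon. The oxime ether chain of the shared core thus grows from propoxy to cyclohexylmethoxy, without any change in donors, acceptors or charge.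

For the measured compounds named here, no measured pair isolates this change, so the expectation rests on compound 1 alone. The step from compound 1 to compound 3 is expected to be small, a 1.3-fold higher number from compound 1 to compound 3 (0.12 log units; within the scatter), within or close to the scatter in either direction. Compound 3 is therefore estimated at 40 nM, with a range from 10 nM to 160 nM in this assay.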

Compound 3, half-maximal inhibitory concentration: 16100 nM
Compound 3: middle estimate off by 400-fold (2.60 log units), on the low side, and the stated range ends below it.
By their numbers in this assay, from the lowest: compound 1; then compound 2; then compound 3.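

In this assay, putting cyclohexyl in place of ethyl on a saturated chain carbon bound to an oxygen on an unsaturated carbon gives a 540-fold higher number from compound 1 to compound 3 (2.73 log units; beyond the scatter) and shows that the outer end of the oxime ether chain does not accept just any carbon group. The swap leaves the count of hydrogen-bond donors, hydrogen-bond acceptors and net charge unchanged: ethyl, with 2 heavy atoms and no ring, gives way to cyclohexyl, with 6 heavy atoms and one six-membered non-aromatic ring of carbon only, so a change made of carbon alone is enough to separate these two results by far more than the usual scatter. No supporting measurement is available to explain this large loss of activity.

The compounds shown cannot separate the effect of the ring from that of the added carbons, a question that a straight butyl or pentyl chain or a small cyclopropyl ring at the same place could address. They also leave open how the chain would respond to a group carrying other atoms, such as a terminal amine or a carboxylic acid.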